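Lengthening the alkenyl chain from compound 3 to compound 4

A few compounds are considered here, and "the series" means these few. Any claim that something is new, unique, unknown or untested is made for them only; others in the source may bear on it.

In a functional assay on A549 cells (Homo sapiens) for antiproliferative activity, read by MTT assay, with a stated time of 72 h (a higher number here means a weaker inhibitor, a lower number a stronger inhibitor), compound 3 (`CC/C=C/C(=O)Nc1cccc(Oc2nc(Nc3ccc(OC)nc3)nc3c2CSCC3)c1`) gives 13100 nM. Compound 2 (`C/C=C/C(=O)Nc1cccc(Oc2nc(Nc3ccc(OC)nc3)nc3c2CSCC3)c1`) gives 8040 nM, and compound 1 (`CCC/C=C/C(=O)Nc1cccc(Oc2nc(Nc3cccc(OC)c3)nc3c2CSCC3)c1`) gives 11800 nM. All three values lie within the scatter of one another.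

Compound 4 (`CCC/C=C/C(=O)Nc1cccc(Oc2nc(Nc3ccc(OC)nc3)nc3c2CSCC3)c1`) differs from compound 3 by methyl in place of hydrogen on a saturated chain carbon, two bonds along the chain from a double-bonded chain carbon. The nearest measured step is a 1.6-fold higher number from compound 2 to compound 3 (0.21 log units; within the scatter), which stays within the scatter. No change beyond the scatter is therefore expected in this assay. The expected step is a 1.0-fold lower number from compound 3 to compound 4 (0.00 log units; within the scatter). For compound 4 the estimate is 13000 nM, with an expected range of 7000 nM to 24000 nM.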

Compound 4, half-maximal inhibitory concentration: 10800 nM
Compound 4: middle estimate off by 1.2-fold (0.08 log units), on the high side; measured number inside the range.
By their numbers in this assay, from the lowest: compounds 2, 4, 1 and 3 (each within the scatter of the next).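

In this assay, the added methyl that turns but-1-en-1-yl into pent-1-en-1-yl brings a 1.2-fold lower number from compound 3 to compound 4 (0.08 log units; within the scatter), and ethyl in place of hydrogen on the chain brings a 1.3-fold higher number from compound 2 to compound 4 (0.13 log units; within the scatter), so the longest chain here still sits within the scatter of both shorter ones. With pent-1-en-1-yl held fixed, 6-methoxypyridin-3-yl in place of 3-methoxyphenyl brings a 1.1-fold lower number from compound 1 to compound 4 (0.04 log units; within the scatter), so this aryl change also leaves the number within the scatter. No evidence on the origin of these steps is available.

As far as these compounds go, whether a longer chain, an amine or a carboxylic acid in place of pent-1-en-1-yl would move the number beyond the scatter stays open.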